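The compounds below may be only part of what the source reports. "The series", "measured", "known", "first", "only" and "open" are said of these compounds alone.

In an ADME assay on BJ cells (Homo sapiens), read by MTT assay, with a stated time of 72 h (on this read-out lower numbers stand for stronger inhibition and higher numbers for weaker inhibition), compound 1 `CNc1ncnc2c1c(-c1ccoc1)cn2[C@@H]1O[C@H](CO)[C@@H](O)[C@H]1O` gives 96300 nM. Compound 2 `CNc1ncnc2c1c(-c1ccsc1)cn2[C@@H]1O[C@H](CO)[C@@H](O)[C@H]1O` returns only a limit, > 100000 nM. For the measured compounds named here, compound 3 `C#Cc1cn([C@@H]2O[C@H](CO)[C@@H](O)[C@H]2O)c2ncnc(NC)c12` gives 86000 nM, which stands within the scatter of the one other exact number: a 1.1-fold lower number from compound 1 to compound 3 (0.05 log units; within the scatter). The remaining steps, an at least 1.0-fold higher number from compound 1 to compound 2 (0.01 log units; that floor lies within the scatter) and an at least 1.1-fold lower number from compound 2 to compound 3 (0.06 log units; that floor lies within the scatter), also show nothing beyond the scatter. Compound 4 `C#Cc1cn([C@@H]2O[C@H](CO)[C@@H](O)[C@H]2O)c2ncnc(N(C)C)c12` differs from compound 3 by methyl in place of hydrogen on a nitrogen on an aromatic ring, methylamino to dimethylamino. All measured steps change the group on an aromatic carbon and none changes this nitrogen, so they bear only indirectly, as a flat series near (the limit of > 100000 nM in this assay, at which 1 of the 3 values shown sits). The expected change is a 1.0-fold higher number from compound 3 to compound 4 (0.02 log units; within the scatter), with no step beyond the scatter. For compound 4 the estimate is 90000 nM, with a range of 40000 nM to 100000 nM.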

Compound 4, half-maximal inhibitory concentration: 410 nM
Estimate against measurement, compound 4: 220-fold (2.34 log units) above; measured number outside the range, below it.
By their numbers in this assay, from the lowest: compound 4; then compounds 3 and 1 (each within the scatter of the next). At a limit, above all of these: compound 2.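

In this assay, the change on the nitrogen on an aromatic ring, methylamino to dimethylamino, gives a 210-fold lower number from compound 3 to compound 4 (2.32 log units; beyond the scatter). For the compounds shown here, this single added methyl is the first step beyond the scatter, so this nitrogen is a position where the read-out can move strongly. The changes on the aromatic carbon gave no such sign, and that flat series lay close to the limit: the limit of > 100000 nM in this assay, at which 1 of the 4 values shown sits.

Going by these compounds alone, only this one pair carries the change, so it remains open whether dimethylamino acts alike with furan-3-yl or thiophen-3-yl on the aromatic carbon. As far as these compounds go, how an unsubstituted amine, diethylamino or pyrrolidine on this nitrogen would read also stays open.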